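Swapping a carbamate for a tertiary amine on the hydroxypiperidine side chain

A few compounds are considered here, and "the series" means these few. Any claim that something is new, unique, unknown or untested is made for them only; others in the source may bear on it.

Measured so far:
compound 1 `Cc1ccccc1CNCC1(O)CCN(CCCc2c[nH]c3ccc(-n4cnnc4)cc23)CC1`: 83 nM
compound 2 `CC(C)(C)OC(=O)NCC1(O)CCN(CCCc2c[nH]c3ccc(-n4cnnc4)cc23)CC1`: 340 nM

Both compounds share a core and differ only in the group attached to the amine nitrogen on the side chain. In an assay on CHO cells with 5-hydroxytryptamine receptor 1B (Homo sapiens) as the target (a higher number here means a weaker inhibitor, a lower number a stronger inhibitor), compound 1 gives 83 nM, while compound 2 gives 340 nM. Among the compounds with values here, compound 2 therefore stands as the higher of the two numbers; the only measured step, a 4.1-fold higher number from compound 1 to compound 2 (0.61 log units; beyond the scatter), lies beyond the scatter.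

Compound 3 `CN(CC1CCCCC1)CC1(O)CCN(CCCc2c[nH]c3ccc(-n4cnnc4)cc23)CC1` has not yet been measured. It differs from compound 2 by (cyclohexylmethyl)(methyl)amino in place of (tert-butoxycarbonyl)amino on a saturated chain carbon bound to a saturated ring carbon. This change removes the tert-butoxycarbonyl that entered in the step from compound 1 to compound 2 and restores an amine bearing carbon substituents, as in compound 1. Within the data shown here, the one measured step that bears on it, a 4.1-fold higher number from compound 1 to compound 2 (0.61 log units; beyond the scatter), ran in the opposite direction, from an alkyl-substituted amine to a carbamate. A step back toward lower numbers is therefore expected for compound 3, of a size comparable to that one, though the new substituents are not the same as those of compound 1.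

Compound 3 is estimated at 110 nM (range 35 nM to 350 nM), that is an expected step of a 3.1-fold lower number from compound 2 to compound 3 (0.49 log units; beyond the scatter).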

Compound 3, half-maximal inhibitory concentration: 27 nM
Estimate against measurement, compound 3: 4.1-fold (0.61 log units) above; measured number outside the range, below it.
By their numbers in this assay, from the lowest: compound 3; then compound 1; then compound 2.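

In this assay, replacing the (tert-butoxycarbonyl)amino group with (cyclohexylmethyl)(methyl)amino gives a 13-fold lower number from compound 2 to compound 3 (1.10 log units; beyond the scatter), so a second amine, with different carbon substituents from those of compound 1, also gives a lower number than the carbamate. The substituents on the amine matter too: exchanging (2-methylbenzyl)amino for (cyclohexylmethyl)(methyl)amino gives a 3.1-fold lower number from compound 1 to compound 3 (0.49 log units; beyond the scatter), which shows that this position distinguishes between amines and not only between amines and a carbamate. No measurements are available here that explain why either change lowers the number.

As far as these compounds go, the step to compound 3 changes two things at once, adding a methyl group on the nitrogen and replacing the 2-methylbenzyl group with cyclohexylmethyl, so the contribution of each remains open. A (cyclohexylmethyl)amino group or a (2-methylbenzyl)(methyl)amino group would separate the two, while a longer chain between the cyclohexane ring and the nitrogen would show whether the distance between them also matters.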